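Triazole-Linked Terpenoid Analogues Tested for HL-60 Cytotoxicity

The compounds below may be only part of what the source reports. "The series", "measured", "known", "first", "only" and "open" are said of these compounds alone.

Compound 1 `C=C1C[C@]23C[C@@]1(O)CC[C@@H]2c1cccc(C)c1[C@@H]3Cn1cc(-c2ccc(OC)cc2)nn1`: in a functional assay on HL-60 cells (Homo sapiens) for cytotoxicity, read by MTT assay, with a stated time of 4 days (a lower number here means a stronger inhibitor, a higher number a weaker inhibitor), compound 1 reaches only the limit > 20000 nM.
Compound 2 `C=C1C[C@]23C[C@@]1(O)CC[C@H]2c1ccc(O)c(C)c1[C@@H]3Cn1cc(-c2ccc(F)cc2)nn1`: in this assay compound 2 reaches only the limit > 20000 nM.
Compound 3 `C=C1C[C@]23C[C@@]1(O)CC[C@@H]2c1cccc(C)c1[C@@H]3Cn1cc(-c2ccc(F)cc2)nn1`: in this assay compound 3 reaches only the limit > 20000 nM.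

All three measured compounds sit at the limit of this assay, as the limit of > 20000 nM in this assay, at which 3 of the 3 values shown sit, records, so none of them gives a number. The change from compound 3 to compound 1 is methoxy in place of fluoro on an aromatic carbon, and the step it made, a step that the two limits leave unreadable from compound 3 to compound 1, cannot be read because both ends are limits. Compound 2 carries a different core from compound 3; the difference between the two cores is not broken down here. Compound 4 `C=C1C[C@]23C[C@@]1(O)CC[C@H]2c1ccc(O)c(C)c1[C@@H]3Cn1cc(-c2ccc(OC)cc2)nn1`, not yet measured, arises from compound 2 by the same change, (methoxy in place of fluoro on an aromatic carbon), here on the core of compound 2. Since compound 2 is itself at the limit > 20000 nM, the step from compound 2 to compound 4 is expected to remain unreadable, a step that the limit leaves unreadable from compound 2 to compound 4, and compound 4 is expected to give 30000 nM in this assay, most likely as another limit, within 15000 nM to 80000 nM.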

Compound 4, half-maximal inhibitory concentration: > 20000 nM
Compound 4 ended at the assay's limit (the forecaster's own chance of this, stated with the estimate: 85%); the middle value does not contradict the limit.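

No new step can be read between compound 2 and compound 4, as both stand only at a limit in this assay: the limit of > 20000 nM in this assay, at which 4 of the 4 values shown sit.

What the compounds shown leave open is how the two cores, or 4-fluorophenyl and 4-methoxyphenyl, would compare in this assay on any compound that gives a number there.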